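This account rests on a few compounds, and the source may have more. Where it says the series, first, only, none or still open, it means among the compounds named here.

Going by the values given here, in an ADME assay on HeLaP4-2 cells (Homo sapiens) for cytotoxicity, read by resazurin assay (a higher number here means that more compound is tolerated, a lower number that less compound is tolerated), compound 1 `NCc1ccccc1-c1cccc(-c2cc(=O)n(O)c3ncccc23)c1` gives 9100 nM, the higher of the two numbers measured so far; compound 2 `NCc1ccc(-c2ccc(Cc3cc(=O)n(O)c4ncccc34)cc2)cc1` gives 3300 nM, a gap beyond the scatter. Compound 3 `NCc1cccc(-c2cccc(-c3cc(=O)n(O)c4ncccc34)c2)c1` has not yet been measured in this assay. It differs from compound 1 in one place: 3-(aminomethyl)phenyl in place of 2-(aminomethyl)phenyl on an aromatic carbon. Among the compounds with values here, no measured pair shows this change, so its effect on the tolerated concentration is unknown; a step of modest size, likely within the scatter and in either direction, is expected. Compound 3 is expected to give 7000 nM, in the range 3000 nM to 18000 nM. The step this estimate implies, a 1.3-fold lower number from compound 1 to compound 3 (0.11 log units; within the scatter), is expected to stay within the usual scatter.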

Compound 3, half-maximal cytotoxic concentration: 4900 nM
Estimate against measurement, compound 3: 1.4-fold (0.15 log units) above; low and high end bracket the measured number.
By their numbers in this assay, from the lowest: compounds 2, 3 and 1 (each within the scatter of the next, the first and the last beyond it).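

In this assay, 3-(aminomethyl)phenyl in place of 2-(aminomethyl)phenyl on an aromatic carbon gives a 1.9-fold lower number from compound 1 to compound 3 (0.27 log units; within the scatter). At this position, the first read on this change shows that relocating the aminomethyl group on the ring, with the same atoms and the same counts of donors and acceptors, produces no step beyond the scatter. Nothing measured on these compounds gives a cause for this step. From the compounds shown here alone, whether the tolerated concentration would hold with a carboxylic acid or a longer amine chain in place of the aminomethyl group stays open. A single step also cannot show how other changes at this position behave.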